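The source may report more compounds than this note shows. Statements on the series, on what has been measured and on what is new or still open speak of the compounds shown alone.

Measured compounds in a functional assay on MDA-MB-231 cells (Homo sapiens) for antiproliferative activity, read by MTT assay, with a stated time of 72 h; a higher number here means a weaker inhibitor, a lower number a stronger inhibitor:
- compound 1 `CC1(C)C/C(=N\OC(=O)c2cccc(NC(=O)c3cccc(F)c3)c2)c2c(-c3ccc(F)cc3)noc2C1` gives > 25000 nM, which is a limit of the assay
- compound 2 `COc1ccc(-c2noc3c2/C(=N/OC(=O)c2cccc(NC(=O)c4cccc(F)c4)c2)CC(C)(C)C3)cc1OC` gives > 25000 nM, which is a limit of the assay
- compound 3 `Nc1cccc(C(=O)Nc2cccc(C(=O)O/N=C3\CCCc4onc(-c5ccc(F)cc5)c43)c2)c1` gives > 25000 nM, which is a limit of the assay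

Compound 1 and compound 2 differ in one place: 3,4-dimethoxyphenyl in place of 4-fluorophenyl on an aromatic carbon. In this assay that change made a step that the two limits leave unreadable from compound 1 to compound 2, and its size cannot be read because of the limit of > 25000 nM in this assay, at which 3 of the 3 values shown sit. Compound 4 `COc1ccc(-c2noc3c2/C(=N/OC(=O)c2cccc(NC(=O)c4cccc(N)c4)c2)CCC3)cc1OC` is not yet measured. It differs from compound 3 by the same change: 3,4-dimethoxyphenyl in place of 4-fluorophenyl on an aromatic carbon. The difference between the core of compound 1 and the core of compound 3 is not broken down here. Within the data shown here, since the only example of this change sits entirely at the limit, compound 4 is expected to stay there as well, an estimated step that the limit leaves unreadable from compound 3 to compound 4. Compound 4 is therefore expected to give about 30000 nM in this assay, most likely reported only as a limit.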

Compound 4, half-maximal inhibitory concentration: > 25000 nM
Compound 4 ended at the assay's limit; the forecaster's own chance of this, stated with the estimate: 85%; the middle value is on the limit's open side.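

No size can be read for the change from compound 3 to compound 4, as both values are limits and not numbers: the limit of > 25000 nM in this assay, at which 4 of the 4 values shown sit.

The compounds shown leave open whether swapping 4-fluorophenyl for 3,4-dimethoxyphenyl changes activity at all.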